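The source may report more compounds than this note shows. Statements on the series, on what has been measured and on what is new or still open speak of the compounds shown alone.

Working notes on the series, read in a functional assay on SK-MEL-2 cells (Homo sapiens) for antiproliferative activity, read by sulforhodamine B assay, with a stated time of 48 h; on this read-out higher numbers stand for weaker inhibition and lower numbers for stronger inhibition.

Compound 3 `O=C(Nc1ccc(-n2cc(-c3ccncc3)c(-c3ccc(Cl)c(O)c3)n2)cc1)c1ccc(Cl)c(Cl)c1` gives 4050 nM in this assay. Compound 2 `O=C(Nc1ccc(-n2cc(-c3ccncc3)c(-c3ccc(Cl)c(O)c3)n2)cc1)Nc1ccc(Cl)c(C(F)(F)F)c1` gives 1700 nM. Compound 1 `COc1cc(-c2nn(-c3ccc(NC(=O)c4cc(Cl)cc(Cl)c4)cc3)cc2-c2ccncc2)ccc1Cl` reaches only the limit of this assay, > 100000 nM, and is a limit rather than a number. Of the two numbers given, compound 3 holds the higher one, with compound 2 nearest: the step of a 2.4-fold higher number from compound 2 to compound 3 (0.38 log units; beyond the scatter) exchanges the whole group on the carbonyl carbon and is modest in size.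

Compound 4 `O=C(Nc1ccc(-n2cc(-c3ccncc3)c(-c3ccc(Cl)c(O)c3)n2)cc1)c1cc(Cl)cc(Cl)c1` differs from compound 3 by 3,5-dichlorophenyl in place of 3,4-dichlorophenyl on a carbonyl carbon. Among the measured compounds shown here, no measured step covers this swap of one dichlorophenyl for the other. For the measured compounds named here, the only measured step, a 2.4-fold higher number from compound 2 to compound 3 (0.38 log units; beyond the scatter), concerns a larger exchange at the same carbonyl carbon and still stayed modest, so the change from compound 3 to compound 4 is expected to be small as well. Compound 1 also carries the 3,5-dichlorophenyl on a carbonyl carbon, but differs from compound 3 in a second place too, so its limit of > 100000 nM in this assay, at which 1 of the 3 values shown sits, cannot be read as a step and is not used here.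

The step from compound 3 to compound 4 is therefore estimated as a 1.5-fold higher number from compound 3 to compound 4 (0.17 log units; within the scatter) in this assay, a shift that may not exceed the scatter. Compound 4 is expected to give 6000 nM, between 2000 nM and 25000 nM.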

Compound 4, half-maximal inhibitory concentration: 6910 nM
Beside the measured number, compound 4's estimate is 1.2-fold (0.06 log units) below it; the range from low to high includes it.
By their numbers in this assay, from the lowest: compound 2; then compounds 3 and 4 (each within the scatter of the next). At a limit, above all of these: compound 1.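

In this assay, exchanging one dichlorophenyl for the other on a carbonyl carbon whose other neighbour is an amide-type nitrogen gives a 1.7-fold higher number from compound 3 to compound 4 (0.23 log units; within the scatter), so these numbers do not separate the 3,4-dichlorophenyl from the 3,5-dichlorophenyl. Placing 3,5-dichlorophenyl on that carbon instead of (4-chloro-3-(trifluoromethyl)phenyl)amino gives a 4.1-fold higher number from compound 2 to compound 4 (0.61 log units; beyond the scatter), which is beyond the scatter and runs the same way as a 2.4-fold higher number from compound 2 to compound 3 (0.38 log units; beyond the scatter), so both dichlorophenyl exchanges now read as modest steps to higher numbers. With the 3,5-dichlorophenyl held constant, hydrogen in place of methyl on an oxygen on an aromatic ring gives an at least 14-fold lower number from compound 1 to compound 4 (1.16 log units; beyond the scatter), a large step whose starting point is the limit held by compound 1, not a number: the limit of > 100000 nM in this assay, at which 1 of the 4 values shown sits.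

From the compounds shown here alone, it remains open how an ethyl on that oxygen, or an amine in place of the oxygen group, would read, and whether the same large step appears with the 3,4-dichlorophenyl. Also open, going by these compounds, are (3,5-dichlorophenyl)amino on the carbonyl carbon, which would separate the amino link from the ring pattern, and a nitrile in place of a chlorine on the phenyl.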